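The source may report more compounds than this note shows. Statements on the series, on what has been measured and on what is new or still open speak of the compounds shown alone.

Among the measured compounds shown here, compound 2 `O=C(NS(=O)(=O)CCNC(=O)C1CC1)c1ccc(Nc2nc(NC3(c4ccc(Cl)cc4)CC3)nc(OCC(F)(F)F)n2)cc1` is one of three compounds measured in an ADME assay on microsomes from liver (Homo sapiens) for metabolic stability, with a stated time of 10 min; a lower number here means that less of the compound is left, a higher number that more of the compound is left. In this assay compound 2 gives 90%. Compound 1 `CCCCCNc1nc(Nc2ccc([N+](=O)[O-])cc2)nc(OCC(F)(F)F)n1` gives 74% in this assay, a number beyond the scatter lower than that of compound 2. Compound 3 `CC(C)OC(=O)NCCS(=O)(=O)NC(=O)c1ccc(Nc2nc(NC3(c4ccc(Cl)cc4)CC3)nc(OCC(F)(F)F)n2)cc1` gives 100% in this assay, so compound 2 stands second highest of the three, with compound 3 nearest and compound 1 furthest. The only step among these that changes the group on the carbonyl carbon, a number 10 percentage points higher from compound 2 to compound 3 (within the scatter), lies within the scatter. Compound 4 `CNC(=O)NCCS(=O)(=O)NC(=O)c1ccc(Nc2nc(NC3(c4ccc(Cl)cc4)CC3)nc(OCC(F)(F)F)n2)cc1` differs from compound 2 in the same place: methylamino in place of cyclopropyl on a carbonyl carbon, or, cut one bond further out, cyclopropylcarbonyl to methylcarbamoyl. Since the step from compound 2 to compound 3 at this carbonyl carbon stayed within the scatter, the step from compound 2 to compound 4 is expected to be a number 2 percentage points higher from compound 2 to compound 4 (within the scatter), not beyond the scatter. Compound 4 is therefore estimated to give 92% in this assay, within a range from 78% to 100%.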

Compound 4, percent of the compound remaining: 97%
For compound 4 the middle estimate is 5 percentage points below the measured one; low and high end bracket the measured number.
By their numbers in this assay, from the lowest: compound 1; then compounds 2, 4 and 3 (each within the scatter of the next).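

In this assay, methylamino now joins isopropoxy as a second replacement for cyclopropyl on this carbonyl carbon, with a number 7 percentage points higher from compound 2 to compound 4 (within the scatter), and the comparison between the two replacements gives a number 3 percentage points lower from compound 3 to compound 4 (within the scatter). All three listed steps at this place therefore stay within the scatter, even though this change removes the three-membered ring of carbon only and brings in a hydrogen-bond donor, so the read-out does not separate cyclopropyl, isopropoxy and methylamino here. No supporting measurement bears on why these groups read alike.

From the compounds shown here alone, whether a phenyl ring, a longer chain or a dimethylamino group on this carbonyl carbon would also stay within the scatter remains open. Compound 1 differs from the other compounds in more than one place, so its value cannot be tied to any single group.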